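The source may report more compounds than this note shows. Statements on the series, on what has been measured and on what is new or still open speak of the compounds shown alone.

Measured compounds:
- compound 1, `CCC(=O)N1N=C(c2ccc(C)cc2)CC1c1cn(-c2ccccc2)nc1-c1ccc(Cl)c(Cl)c1`: 29.8%
- compound 2, `CCC(=O)N1N=C(c2ccc(F)cc2)CC1c1cn(-c2ccccc2)nc1-c1ccc(Cl)c(Cl)c1`: 51.1%

In a functional assay on the whole organism (strain Wistar) for inhibition, with Rattus norvegicus as the target, read by paw edema, with a stated time of 30 min, at a dose of 50 mg/kg by the oral route (a higher number here means more inhibition at the dose given (going by the name of the read-out), a lower number less inhibition), compound 1 gives 29.8%, the lower of the two numbers recorded. Among the measured compounds shown here, compound 2 gives 51.1%, so the step of a number 21.3 percentage points higher from compound 1 to compound 2 (beyond the scatter) is the only measured change in this set.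

Compound 3, `Cc1ccc(C2=NNC(c3cn(-c4ccccc4)nc3-c3ccc(Cl)c(Cl)c3)C2)cc1`, differs from compound 1 in one place: hydrogen in place of propanoyl on an amine nitrogen in a ring. For the measured compounds named here, no measured step touches this part of the shared core; the one step known, a number 21.3 percentage points higher from compound 1 to compound 2 (beyond the scatter), concerns a substituent on an aromatic carbon and says nothing about the ring nitrogen. Going by the values given here, the step from compound 1 to compound 3 therefore has no measured precedent, and the expectation rests on compound 1 alone. On that basis compound 3 is expected to stay near compound 1, with a step of a number 0.2 percentage points higher from compound 1 to compound 3 (within the scatter) that is not expected to exceed the scatter. The estimate for compound 3 in this assay is 30%, within a range from 10% to 55%.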

Compound 3, a percentage reported as inhibition, in the whole organism at one dose (the size of the read-out at that dose, not a potency): 38.3%
Compound 3: middle estimate off by 8.3 percentage points, on the low side, within the range that was stated.
By their numbers in this assay, from the lowest: compounds 1 and 3 (each within the scatter of the next); then compound 2.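

Hydrogen in place of propanoyl on the amine nitrogen in the ring is the first measured change at this position, and in this assay the step is a number 8.5 percentage points higher from compound 1 to compound 3 (within the scatter). With the 4-methylphenyl group in place, the propanoyl group can therefore give way to hydrogen with the two numbers remaining within the scatter of each other, something the earlier step on an aromatic carbon could not show. Nothing measured here explains this result.

The compounds shown leave open whether the same replacement would stay within the scatter with the fluoro group of compound 2 in place of the methyl group. They also leave open how a butanoyl chain, a benzoyl group or an acetyl group on this ring nitrogen would read in this assay.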